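A few compounds are considered here, and "the series" means these few. Any claim that something is new, unique, unknown or untested is made for them only; others in the source may bear on it.

Series notes. In a functional assay on ileum (Cavia porcellus) with cysteinyl leukotriene receptor (Homo sapiens) as the target (on this read-out higher numbers stand for higher potency (the scale is a negative logarithm) and lower numbers for lower potency), compound 1 `CCCc1c(COc2ccc(C(=O)CCc3nnn[nH]3)cc2)ccc(C(C)=O)c1O` gives 7.09. Compound 2 `CCCc1c(COc2ccc(C(=O)C(C)Cc3nnn[nH]3)cc2)ccc(C(C)=O)c1O` carries a methyl in place of hydrogen on a saturated chain carbon bound to a carbonyl carbon and a saturated chain carbon; in this assay compound 2 gives 7.18. Going by the values given here, the only measured step so far is a number 0.09 log units higher from compound 1 to compound 2 (within the scatter). Compound 2 stands highest of the two numbers, with compound 1 nearest and within the scatter of it, so no order between the two can be read. Compound 3 `CCCc1c(COc2ccc(C(=O)CC(C)(C)CC(=O)O)cc2)ccc(C(C)=O)c1O` differs from compound 2 by 2-(carboxymethyl)-2-methylpropyl in place of 1-((1H-tetrazol-5-yl)methyl)ethyl on a carbonyl carbon. Among the compounds with values here, no measured step bears on this exchange: the step between compound 1 and compound 2 alters only a chain hydrogen and tells nothing about swapping the leaving group for the entering one. The expectation therefore rests on the change alone and is held loose; a modest loss is expected, a number 0.38 log units lower from compound 2 to compound 3 (beyond the scatter). Compound 3 is estimated at 6.8, with a range from 6 to 7.6.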

Compound 3, negative logarithm of the antagonist equilibrium constant: 7.73
Compound 3: middle estimate off by 0.93 log units, on the low side; measured number outside the range, above it.
By their numbers in this assay, from the lowest: compounds 1 and 2 (each within the scatter of the next); then compound 3.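

In this assay, going by these compounds alone, 2-(carboxymethyl)-2-methylpropyl in place of 1-((1H-tetrazol-5-yl)methyl)ethyl on a carbonyl carbon gives a number 0.55 log units higher from compound 2 to compound 3 (beyond the scatter) and is the first change to move the number beyond the scatter. Read against the unbranched chain, 1-(carboxymethyl)-1-methylethyl in place of (1H-tetrazol-5-yl)methyl gives a number 0.64 log units higher from compound 1 to compound 3 (beyond the scatter) and is also modest, so the five-membered aromatic ring is not needed for the highest number among these compounds. Nothing measured bears on the reason for this rise.

The exchange alters the end group and the branching of the chain together, and the compounds shown do not separate the two. From the compounds shown here alone, whether an unbranched chain ending in the same carboxylic acid, a longer chain, or a primary amide at the chain end would hold this level remains open.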